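Urea isomers tested for sterol O-acyltransferase inhibition

The source may report more compounds than this note shows. Statements on the series, on what has been measured and on what is new or still open speak of the compounds shown alone.

Compound 1 `CCCCCCN(CCCCCC)C(=O)Nc1ccc(C)cc1C`: 0.11 ug/mL
Compound 2 `Cc1cc(C)c(NC(=O)N(Cc2ccccc2)Cc2ccccc2)cc1C`: 0.16 ug/mL

Two ureas have been measured in an assay on isolated protein for inhibition of sterol O-acyltransferase 1 (Rattus norvegicus); a higher number here means a weaker inhibitor, a lower number a stronger inhibitor. Compound 1 gives 0.11 ug/mL and compound 2 gives 0.16 ug/mL. Compound 2 holds the higher of the two numbers, but its gap to compound 1 lies within the scatter, so the two compounds cannot be told apart on potency.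

Compound 3 `Cc1cc(C)c(NC(=O)N(Cc2ccccc2)Cc2ccccc2)c(C)c1` is an isomer of compound 2: it carries 2,4,6-trimethylphenyl in place of 2,4,5-trimethylphenyl on an amide-type nitrogen. Among the compounds with values here, no measured pair in this set shows what moving a methyl group around the aromatic ring does in this assay, so there is no step to lean on. With the same atoms joined only slightly differently, the step of a 1.1-fold lower number from compound 2 to compound 3 (0.03 log units; within the scatter) is expected to stay within the scatter, in no particular direction. Compound 3 is therefore estimated at 0.15 ug/mL, with a range from 0.05 ug/mL to 0.45 ug/mL.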

Compound 3, half-maximal inhibitory concentration: 1.34 ug/mL
Estimate against measurement, compound 3: 8.9-fold (0.95 log units) below, outside the stated range (above it).
By their numbers in this assay, from the lowest: compounds 1 and 2 (each within the scatter of the next); then compound 3.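

On the amide-type nitrogen whose other neighbours are the carbonyl carbon, the arrangement of the methyl groups on the aromatic ring matters in this assay: 2,4,6-trimethylphenyl in place of 2,4,5-trimethylphenyl gives an 8.4-fold higher number from compound 2 to compound 3 (0.92 log units; beyond the scatter), which makes compound 3 the weaker inhibitor of this pair. Both groups are made of the same atoms and carry the same aromatic ring, so this position responds to a rearrangement alone, with no change in composition. Nothing available explains why this rearrangement has such an effect on the number.

The compounds shown leave open whether the same change would give a step of similar size in a urea carrying the two hexyl chains of compound 1 in place of the two benzyl groups. They also leave open how this position would respond to a larger group such as 2,6-diisopropylphenyl, or to a phenyl ring bearing chlorine in place of the methyl groups.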